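The source may report more compounds than this note shows. Statements on the series, on what has been measured and on what is new or still open speak of the compounds shown alone.

Measured in a functional assay on A-375 cells (Homo sapiens) for antiproliferative activity, read by MTT assay, with a stated time of 24 h; on this read-out higher numbers stand for weaker inhibition and lower numbers for stronger inhibition:
- Compound 1 `COc1cc(OC)c(-c2coc3cc(OCC(=O)c4cccc(C(F)(F)F)c4)ccc3c2=O)cc1OC`: > 10000 nM, a limit
- Compound 2 `COc1cc(OC)c(-c2coc3cc(OCc4ccc(Br)cc4)ccc3c2=O)cc1OC`: 1000 nM
- Compound 3 `COc1cc(OC)c(-c2coc3cc(OCc4ccc([N+](=O)[O-])cc4)ccc3c2=O)cc1OC`: > 10000 nM, a limit

Compound 3 gives > 10000 nM, which is a limit only. That is the limit of > 10000 nM in this assay, at which 2 of the 3 values shown sit.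

Compound 4 `COc1cc(OC)c(-c2coc3cc(OCc4cccc(Cl)c4)ccc3c2=O)cc1OC` carries 3-chlorophenyl in place of the 4-nitrophenyl of compound 3, on a saturated chain carbon bound to an oxygen on an aromatic ring: 3-chlorophenyl in place of 4-nitrophenyl on a saturated chain carbon bound to an oxygen on an aromatic ring.

Going by the values given here, two measured steps bear on this change. The closest is an at least 10-fold higher number from compound 2 to compound 3 (1.00 log units; beyond the scatter), with nitro in place of bromo on an aromatic carbon. The other is an at least 10-fold lower number from compound 1 to compound 2 (1.00 log units; beyond the scatter). The step that the two limits leave unreadable from compound 1 to compound 3 adds nothing. Among the compounds with values here, no measured compound carries the 3-chlorophenyl group, so the transfer from the 4-bromophenyl of compound 2 is uncertain.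

Compound 4 is expected to fall closer to compound 2 than to compound 3. Compound 2 gives 1000 nM. Compound 4 may still reach the limit of compound 3 in this assay. The expected change is a lower number, an at least 4.0-fold lower number from compound 3 to compound 4 (0.60 log units; beyond the scatter). For compound 4 the estimated value is 2500 nM, with an expected range of 700 nM to 10000 nM.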

Compound 4, half-maximal inhibitory concentration: 980 nM
Compound 4: middle estimate off by 2.6-fold (0.41 log units), on the high side; the range from low to high includes it.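

In this assay, 3-chlorophenyl on the saturated chain carbon restores the activity missing with 4-nitrophenyl, an at least 10-fold lower number from compound 3 to compound 4 (1.00 log units; beyond the scatter), and the same gain appears against (3-(trifluoromethyl)phenyl)carbonyl, an at least 10-fold lower number from compound 1 to compound 4 (1.00 log units; beyond the scatter). A second halogen-bearing phenyl now matches the first, with a 1.0-fold lower number from compound 2 to compound 4 (0.01 log units; within the scatter), so the activity of compound 2 is not unique to 4-bromophenyl. Compound 1 and compound 3 remain limits rather than numbers: the limit of > 10000 nM in this assay, at which 2 of the 4 values shown sit.

Chlorine versus bromine and the place of the halogen on the ring stay unseparated, and 4-chlorophenyl and 3-bromophenyl would be the pair to separate them. Also open, on these data alone, is how unsubstituted phenyl, or a phenyl carrying an amine or a carboxylic acid, would read on the same chain carbon.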